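The source may hold more compounds than are shown below. What is called first, only, known or untested is meant among the compounds shown, and "the series" means these compounds.

Compound 1 `O=C(/C=C/c1ccc(CN2C(=O)/C(=C3\Nc4ccccc4\C3=N/O)c3cc(Cl)ccc32)cc1)NO`: 80 nM
Compound 2 `Cc1ccc2c(c1)/C(=C1/Nc3ccccc3/C1=N\O)C(=O)N2Cc1ccc(/C=C/C(=O)NO)cc1`: 50 nM

For the measured compounds named here, in a functional assay on SW-620 cells (Homo sapiens) for cytotoxicity, read by colorimetric assay (a higher number here means a weaker inhibitor, a lower number a stronger inhibitor), compound 1 gives 80 nM, and it stands level with compound 2, since the only measured step, a 1.6-fold lower number from compound 1 to compound 2 (0.20 log units; within the scatter), stays within the scatter. Compound 3 `O=C(NO)c1ccc(CN2C(=O)/C(=C3\Nc4ccccc4\C3=N/O)c3cc(Cl)ccc32)cc1` differs from compound 1 elsewhere: hydroxycarbamoyl in place of 2-(hydroxycarbamoyl)ethenyl on an aromatic carbon. In words, this is hydroxycarbamoyl in place of 2-(hydroxycarbamoyl)ethenyl on an aromatic carbon. The measured step swaps a different group, so it gives no size for this change, and the guide is weak. A modest move towards a higher number is expected, a 1.9-fold higher number from compound 1 to compound 3 (0.27 log units; within the scatter). Compound 3 is estimated at 150 nM, with an expected range of 40 nM to 500 nM.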

Compound 3, half-maximal inhibitory concentration: 60 nM
Compound 3: middle estimate off by 2.5-fold (0.40 log units), on the high side; measured number inside the range.
By their numbers in this assay, from the lowest: compounds 2, 3 and 1 (each within the scatter of the next).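

For the compounds shown here, putting hydroxycarbamoyl in place of 2-(hydroxycarbamoyl)ethenyl gives a 1.3-fold lower number from compound 1 to compound 3 (0.12 log units; within the scatter) in this assay, the first step at this position, since the earlier step changed only chloro to methyl elsewhere on the core. This aromatic carbon, para to a large group, therefore carries either group with no measurable difference in this assay. Nothing available explains why the two groups read alike. Still open, going by these compounds, is how a carboxylic acid or a longer chain would read at this position. Also open, on these data alone, is whether methyl in place of chloro would read the same alongside hydroxycarbamoyl.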